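This account rests on a few compounds, and the source may have more. Where it says the series, first, only, none or still open, it means among the compounds named here.

Measured compounds:
- compound 1 `C#CCO/N=C/c1c(-c2ccc(F)cc2)nc2c(C)cccn12`: 100 mg/kg
- compound 2 `COc1ccc(Cn2cc(CO/N=C/c3c(-c4ccc(F)cc4)nc4c(C)cccn34)nn2)cc1`: 40 mg/kg
- compound 3 `Cc1ccc(-c2nc3ccc(Br)cn3c2/C=N/OCc2cn(Cc3ccc(C#N)cc3)nn2)cc1`: 40 mg/kg

All three were tested in a functional assay on the whole organism (strain NMRI) with Mus musculus as the target, with a stated time of 4 h; on this read-out lower numbers stand for an effect already at smaller amounts and higher numbers for an effect only at larger amounts of compound. Compound 1 stands at the highest number of the three, which here means it needs the largest amount to show an effect. The numbers of compound 2 and compound 3 both lie lower than that of compound 1, and in each case the gap is beyond the usual scatter of the measurement.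

Compound 4 `C#CCO/N=C/c1c(-c2ccc(C)cc2)nc2c(C)cccn12` has not yet been measured. It is compound 1 with a single change: methyl in place of fluoro on an aromatic carbon. Among the measured compounds shown here, no pair of measured compounds that differ in just one place is available, so there is nothing to lean on for the size of such a swap. The change is small and keeps the rest of the molecule untouched, so the expected step of no change at the digits printed from compound 1 to compound 4 (within the scatter) is none beyond the scatter, with no clear direction. Compound 4 is therefore estimated at 100 mg/kg in this assay, with a range from 40 mg/kg to 250 mg/kg.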

Compound 4, minimum effective dose: 20 mg/kg
Estimate against measurement, compound 4: 5.0-fold (0.70 log units) above; measured number outside the range, below it.
By their numbers in this assay, from the lowest: compounds 4, 2 and 3 (each within the scatter of the next); then compound 1.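

In this assay, going from 4-fluorophenyl to 4-methylphenyl gives a 5.0-fold lower number from compound 1 to compound 4 (0.70 log units; beyond the scatter) on a change of a single heavy atom, with the rest of the molecule untouched. This shows that the group on this aromatic carbon, para to a large group, is not a bystander: the smallest of swaps here alters the dose needed for an effect, and it is the first size available for any single change among these compounds. Nothing shown explains why methyl and fluoro differ at this position.

From the compounds shown here alone, what a chloro, an ethyl or an amine would do on the same carbon remains open. So does whether the same swap would have a similar effect in compound 2, which also carries the 4-fluorophenyl group.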